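A few compounds are considered here, and "the series" means these few. Any claim that something is new, unique, unknown or untested is made for them only; others in the source may bear on it.

Compound 1 `COc1cc2nc(N3CCN(S(=O)(=O)c4ccc(Br)cc4)CC3)nc(N)c2cc1OC` gives 20000 nM in a functional assay on PC-3 cells (Homo sapiens) for inhibition; on this read-out lower numbers stand for stronger inhibition and higher numbers for weaker inhibition. Compound 2 `COc1cc2nc(N3CCN(S(=O)(=O)c4ccc(I)cc4)CC3)nc(N)c2cc1OC` gives 15000 nM. Compound 3 `COc1cc2nc(N3CCN(S(=O)(=O)c4ccccc4[N+](=O)[O-])CC3)nc(N)c2cc1OC` gives 35000 nM.

Compound 3 thus shows the highest of the three numbers: the step of a 1.8-fold higher number from compound 1 to compound 3 (0.24 log units; within the scatter) stays within the scatter, while the step of a 2.3-fold higher number from compound 2 to compound 3 (0.37 log units; beyond the scatter) is modest but beyond it. Compound 4 `COc1cc2nc(N3CCN(S(=O)(=O)c4ccc([N+](=O)[O-])cc4)CC3)nc(N)c2cc1OC` differs from compound 3 by 4-nitrophenyl in place of 2-nitrophenyl on a sulfonyl sulfur. Both earlier steps altering the group on the sulfonyl sulfur shifted the number only slightly, and compounds 1 and 2, which carry a 4-substituted phenyl there, show the lower numbers. Accordingly, a small lowering is expected, the step of a 1.6-fold lower number from compound 3 to compound 4 (0.20 log units; within the scatter) lying near the edge of the scatter. Compound 4 is therefore expected to give about 22000 nM, within a range from 9000 nM to 55000 nM.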

Compound 4, half-maximal inhibitory concentration: 36000 nM
For compound 4 the middle estimate is 1.6-fold (0.21 log units) below the measured one, and the stated range covers the measured number.
By their numbers in this assay, from the lowest: compounds 2, 1, 3 and 4 (each within the scatter of the next, the first and the last beyond it).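

With 4-nitrophenyl in place of 2-nitrophenyl on the sulfonyl sulfur, a 1.0-fold higher number from compound 3 to compound 4 (0.01 log units; within the scatter) in this assay shows that the two nitrophenyl groups cannot be told apart here. Nitro in place of iodo gives a 2.4-fold higher number from compound 2 to compound 4 (0.38 log units; beyond the scatter) and is modest, whereas nitro in place of bromo gives a 1.8-fold higher number from compound 1 to compound 4 (0.26 log units; within the scatter) and stays within the scatter, so compound 4 goes against any link between a 4-substituted phenyl and a lower number. Nothing available explains these numbers.

Going by these compounds, it remains open whether an amine or a carboxylic acid on the phenyl would give a clearly lower number. The same holds for a longer chain in place of the phenyl on the sulfonyl sulfur.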